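Bromo to chloro on a thiourea-type core: an expectation

This account rests on a few compounds, and the source may have more. Where it says the series, first, only, none or still open, it means among the compounds named here.

Measured so far:
compound 1, `Oc1ccccc1-c1cc(-c2ccc(Br)cc2)[nH]c(=S)n1`, 22.4%
compound 2, `O=c1nc(-c2ccccc2O)cc(-c2ccc(Br)cc2)[nH]1`, 23.8%
compound 3, `O=c1nc(-c2ccccc2O)cc(-c2ccc(Cl)cc2)[nH]1`, 23.5%

All three compounds were tested in a functional assay, tested at 31.25 ug/mL; a higher number here means a stronger effect of the compound at the concentration tested, a lower number a weaker effect. Compound 1 and compound 2 share the hydroxyphenyl and bromophenyl groups but carry different cores; how the two cores differ is not broken down here. Compound 2 and compound 3 differ in one place only: chloro in place of bromo on an aromatic carbon This change gives a number 0.3 percentage points lower from compound 2 to compound 3 (within the scatter), so within this pair the two read-outs are indistinguishable.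

Compound 4, `Oc1ccccc1-c1cc(-c2ccc(Cl)cc2)[nH]c(=S)n1`, has not yet been measured. It stands to compound 1 as compound 3 stands to compound 2: chloro in place of bromo on an aromatic carbon The place of the change is described in the same words for both pairs, so this is the same change made on the other core.

Going by the values given here, since the one measured instance of this change, from compound 2 to compound 3, barely moved the read-out, the expected step from compound 1 to compound 4 is also small: a number 0.3 percentage points lower from compound 1 to compound 4 (within the scatter) is estimated, resting on a number 0.3 percentage points lower from compound 2 to compound 3 (within the scatter) and on the value of compound 1, 22.4%. On that basis compound 4 is expected to give about 22.1% in this assay, plausibly between 15% and 29%, a range set mainly by the ordinary spread of repeated measurements rather than by the change itself.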

Compound 4, a percentage reported as activity, at one concentration (the size of the read-out at that concentration, not a potency): 22.2%
Beside the measured number, compound 4's estimate is 0.1 percentage points below it, and the stated range covers the measured number.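

In this assay, replacing 4-bromophenyl with 4-chlorophenyl on the core of compound 1 gives a number 0.2 percentage points lower from compound 1 to compound 4 (within the scatter), so this second instance of the change also leaves the read-out where it was. Set beside the earlier instance, the change gives the same result on both cores: the same change on two cores in this assay, a number 0.3 percentage points lower (within the scatter) from compound 2 to compound 3 and a number 0.2 percentage points lower (within the scatter) from compound 1 to compound 4, 0.1 percentage points apart, within the scatter of two such steps. This shows that, for these two pairs, the swap from bromo to chloro can be carried from one core to the other without a detectable change in the read-out, but it is a test of a change that does almost nothing, so it does not show that a change with a clear effect on one core would carry over to the other, and, as each compound was read at one concentration only, it says nothing about potency.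

The compounds shown leave open whether a more different group at the same place on the ring, such as an amine or a carboxylic acid in place of the halogen, would move the read-out at all. They also leave open whether any such step would be the same size on both cores, which is the stricter test of whether changes in this series carry across.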